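Swapping one side group on a two-compound series

The compounds below may be only part of what the source reports. "The series", "measured", "known", "first", "only" and "open" are said of these compounds alone.

Measured in a functional assay for inhibition, with Homo sapiens as the target; on this read-out higher numbers stand for weaker binding and lower numbers for tighter binding:
Compound 1 `O=C(O)CC/C=C\CC1COC(c2ccc3ccccc3c2)OC1c1cccnc1`: 1780 nM
Compound 2 `CC(C)(Oc1ccccc1Br)C1OCC(C/C=C\CCC(=O)O)C(c2cccnc2)O1`: 63.1 nM

Of these two results, compound 2 has the lower number at 63.1 nM, and its gap to compound 1 lies beyond the usual scatter. The two compounds differ in more than one place, so that gap does not isolate the effect of any single group.

The next compound to be tested is compound 3 `CC(C)(Sc1ccccc1)C1OCC(C/C=C\CCC(=O)O)C(c2cccnc2)O1`. It has phenylsulfanyl in place of 2-bromophenoxy on a saturated chain carbon bound to two saturated chain carbons and a saturated ring carbon. Both groups contain one six-membered aromatic ring of carbon only, and the rest of the structure stays the same.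

Within the data shown here, no measured pair tests this swap, so the expectation is tentative. Compound 2 at 63.1 nM is the closest reference point. A small move to a higher number in this assay is expected, possibly not beyond the scatter, and the direction is uncertain. The expected change is a 1.9-fold higher number from compound 2 to compound 3 (0.28 log units; within the scatter). For compound 3 the estimate is 120 nM, with an expected range of 30 nM to 480 nM.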

Compound 3, dissociation constant: 200 nM
Compound 3: the middle estimate sits 1.7-fold (0.22 log units) below what was measured; measured number inside the range.
By their numbers in this assay, from the lowest: compound 2; then compound 3; then compound 1.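

In this assay, phenylsulfanyl in place of 2-bromophenoxy on a saturated chain carbon bound to two saturated chain carbons and a saturated ring carbon gives a 3.2-fold higher number from compound 2 to compound 3 (0.50 log units; beyond the scatter), so the number responds to this swap even though both groups contain one six-membered aromatic ring of carbon only. Among these compounds, the result also gives the first comparison in which only one place differs on a saturated ring carbon: a group of 10 heavy atoms with one aromatic ring, in place of a group of 10 heavy atoms with two aromatic rings, gives an 8.9-fold lower number from compound 1 to compound 3 (0.95 log units; beyond the scatter), so equal heavy-atom counts still leave a gap beyond the scatter. Nothing measured here bears on why either step has its size.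

The swap trades oxygen for sulfur and drops the bromine in one move, and the compounds shown do not separate these two changes. Where a plain phenoxy group or a 2-bromophenylsulfanyl group would fall in this assay stays open, and either one would help to tell the two changes apart.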